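This account rests on a few compounds, and the source may have more. Where it says the series, first, only, none or still open, it means among the compounds named here.

Compound 1 `Cc1ccc(N2CCN/C2=N\N)cc1` and compound 3 `N/N=C1\NCCN1c1ccccc1` share one core and differ in one place: hydrogen in place of methyl on an aromatic carbon. In an ADME assay on Vero cells (Chlorocebus sabaeus) for cytotoxicity, with a stated time of 72 h, tested at 50 ug/mL (a higher number here means a stronger effect of the compound at the concentration tested, a lower number a weaker effect), compound 1 gives 9% and compound 3 gives 0%, so the step of a number 9 percentage points lower from compound 1 to compound 3 (within the scatter) is small.

Compound 2 `Cc1ccc(N2CCn3c2n[nH]c(=O)c3=N)cc1` is built on a different core; the difference between the two cores is not broken down here. In this assay compound 2 gives 0%, level with compound 3 at the digits printed, and the two together stand as the lowest of the three numbers, while compound 1 lies only a little higher, within the scatter.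

Compound 4 `N=c1c(=O)[nH]nc2n1CCN2c1ccccc1` is not yet measured. It stands to compound 2 as compound 3 stands to compound 1: hydrogen in place of methyl on an aromatic carbon. The surroundings of the place are not identical, para to a large group in compound 2 against para to a group of 7 heavy atoms in compound 1, so the change is the same kind of change rather than the same one. Because the matched step a number 9 percentage points lower from compound 1 to compound 3 (within the scatter) stayed within the scatter, the step from compound 2 to compound 4 is expected to be about as small, a number 1 percentage points higher from compound 2 to compound 4 (within the scatter). Compound 4 is therefore expected to give about 1% in this assay.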

Compound 4, a percentage reported as inhibition, at one concentration (the size of the read-out at that concentration, not a potency): 30%
For compound 4 the middle estimate is 29 percentage points below the measured one, and the stated range ends below it.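

On the core of compound 2, putting hydrogen in place of methyl on the aromatic ring gives a number 30 percentage points higher from compound 2 to compound 4 (beyond the scatter) in this assay. The size of this change therefore depends on the core that carries it in this series, and a step read on one core could not simply be carried over to the other: the same change on two cores in this assay, a number 9 percentage points lower (within the scatter) from compound 1 to compound 3 and a number 30 percentage points higher (beyond the scatter) from compound 2 to compound 4, 39 percentage points apart, beyond the scatter of two such steps. Among the compounds shown here, this comparison rests on only one pair of compounds for each core, and it does not show which feature of the core of compound 2 is responsible, or what the same change would do on a third core.

The compounds shown hold only methyl and hydrogen at this place on the aromatic ring, so what a chlorine atom, a methoxy group or a longer chain such as ethyl would do there on either core stays open. On these data alone, the read-out comes from one concentration and is not a potency, so how compound 4 behaves at other concentrations also stays open.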